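Shifting the ring nitrogen in the hydrazone-bearing ring

The source may report more compounds than this note shows. Statements on the series, on what has been measured and on what is new or still open speak of the compounds shown alone.

Measured so far:
Compound 1, `O=C(N/N=C/c1ccc(O)cc1)c1cccnc1Nc1cccc(C(F)(F)F)c1`: in a functional assay on the whole organism (strain Wistar) for inhibition, with Rattus norvegicus as the target, read by paw edema, with a stated time of 30 min, at a dose of 10 mg/kg by the intraperitoneal route (a lower number here means less inhibition, a higher number more inhibition at the dose given (going by the name of the read-out)), compound 1 gives 59.3%.
Compound 2, `COc1ccc(/C=N/NC(=O)c2cccnc2Nc2cccc(C(F)(F)F)c2)cc1`: in this assay compound 2 gives 50.4%.
Compound 3, `O=C(N/N=C/c1cccnc1)c1cccnc1Nc1cccc(C(F)(F)F)c1`: in this assay compound 3 gives 59.1%.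

All three compounds share the same core and differ only in the ring attached to the carbon that carries a double bond to nitrogen. The three numbers lie close together: the step of a number 0.2 percentage points lower from compound 1 to compound 3 (within the scatter) and the step of a number 8.7 percentage points higher from compound 2 to compound 3 (within the scatter) are both within the scatter, as is the step of a number 8.9 percentage points lower from compound 1 to compound 2 (within the scatter). So compound 3 cannot be set apart from either neighbour on these numbers.

Compound 4, `O=C(N/N=C/c1ccncc1)c1cccnc1Nc1cccc(C(F)(F)F)c1`, is not yet measured. It differs from compound 3 by pyridin-4-yl in place of pyridin-3-yl on a carbon with a double bond to nitrogen. Going by the values given here, the steps that bear on this change are those at the same position, from compound 1 to compound 3 and from compound 2 to compound 3, and neither moved the number beyond the scatter, even though those changes swapped a whole ring for another. Moving the nitrogen within an otherwise identical ring is a smaller change still, so in this assay the step of a number 2.1 percentage points lower from compound 3 to compound 4 (within the scatter) is expected to stay within the scatter. Compound 4 is therefore estimated to give 57%, with a range from 45% to 68%.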

Compound 4, a percentage reported as inhibition, in the whole organism at one dose (the size of the read-out at that dose, not a potency): 68.1%
The estimate for compound 4 lay 11.1 percentage points below the measured number; measured number outside the range, above it.
By their numbers in this assay, from the lowest: compounds 2, 3, 1 and 4 (each within the scatter of the next, the first and the last beyond it).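

Going by these compounds alone, at the carbon with a double bond to nitrogen, pyridin-4-yl in place of 4-methoxyphenyl gives a number 17.7 percentage points higher from compound 2 to compound 4 (beyond the scatter) in this assay, the first step at this position to clear the scatter, so the choice of ring here can show up in this read-out, though only modestly so far. Moving the ring nitrogen alone, with atoms and counted features otherwise the same, gives a number 9 percentage points higher from compound 3 to compound 4 (within the scatter) and pyridin-4-yl in place of 4-hydroxyphenyl gives a number 8.8 percentage points higher from compound 1 to compound 4 (within the scatter), so compound 4 can be told apart from compound 2 but from neither of the other two. Nothing available here accounts for the step that clears the scatter.

The compounds shown leave open where a plain phenyl ring, with no ring nitrogen and no substituent, would fall at this position, and whether an amine or a carboxylic acid on the ring would take the number further from that of compound 2. From the compounds shown here alone, all of these readings also come from a single dose and a single time, so whether the step from compound 2 to compound 4 holds under other conditions remains open as well.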